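A few compounds are considered here, and "the series" means these few. Any claim that something is new, unique, unknown or untested is made for them only; others in the source may bear on it.

Compound 2, `N/C(CC(O)c1cccc2ccccc12)=N\N=C\c1ccc(F)cc1`, is a hydrazone carrying a 4-fluorophenyl group. Among the compounds with values here, in an ADME assay on L6 cells (Rattus norvegicus) for cytotoxicity, read by resazurin assay, with a stated time of 72 h (on this read-out lower numbers stand for stronger inhibition and higher numbers for weaker inhibition), compound 2 gives 19000 nM, the highest of the two numbers measured so far. Its nearest neighbour is compound 1, `N/C(CC(O)c1cccc2ccccc12)=N\N=C\c1ccc(Cl)c(Cl)c1`, which in this assay gives 16000 nM; the step of a 1.2-fold higher number from compound 1 to compound 2 (0.07 log units; within the scatter), swapping 3,4-dichlorophenyl for 4-fluorophenyl, stays within the scatter, so the two compounds cannot be told apart on this read-out.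

Compound 3, `N/C(CC(O)c1cccc2ccccc12)=N\N=C\c1ccc(F)c(F)c1`, is the next member: it differs from compound 2 by fluoro in place of hydrogen on an aromatic carbon, turning 4-fluorophenyl into 3,4-difluorophenyl. Within the data shown here, the one step that bears on this, from compound 1 to compound 2, changed the halogen pattern on the same ring without moving the number beyond the scatter. Compound 3 is therefore expected to show a step of a 1.1-fold lower number from compound 2 to compound 3 (0.02 log units; within the scatter), none beyond the scatter. Compound 3 is estimated to give 18000 nM, between 9000 nM and 36000 nM.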

Compound 3, half-maximal inhibitory concentration: 17000 nM
Compound 3: middle estimate off by 1.1-fold (0.02 log units), on the high side; measured number inside the range.
By their numbers in this assay, from the lowest: compounds 1, 3 and 2 (each within the scatter of the next).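

In this assay, placing a fluoro on the aromatic carbon ortho to the existing fluoro group gives a 1.1-fold lower number from compound 2 to compound 3 (0.05 log units; within the scatter), so this added atom leaves the read-out unchanged within the scatter. Keeping the substitution pattern fixed and changing only the halogen, with 3,4-difluorophenyl in place of 3,4-dichlorophenyl, gives a 1.1-fold higher number from compound 1 to compound 3 (0.03 log units; within the scatter), which separates the choice of halogen from the pattern in a way the earlier pair could not. No supporting measurement is available to explain this flat result.

Going by these compounds, all three compounds carry only fluoro or chloro groups on this ring, so it remains open whether an amine, a carboxylic acid or a longer chain there would move the number beyond the scatter. Changes elsewhere on the shared core also remain open.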